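Taking the methoxy group off compound 3

This account rests on a few compounds, and the source may have more. Where it says the series, first, only, none or still open, it means among the compounds named here.

In a functional assay on HeLa cells (Homo sapiens) for inhibition, read by MTT assay, with a stated time of 72 h (on this read-out higher numbers stand for weaker inhibition and lower numbers for stronger inhibition), compound 1 (`Fc1ccc(-c2nnc(SCCCN3CCN(c4nc5ccccc5o4)CC3)o2)cc1`) gives 196000 nM, compound 2 (`Oc1ccc(-c2nnc(SCCCN3CCN(c4nc5ccccc5o4)CC3)o2)cc1`) gives 99500 nM and compound 3 (`COc1ccc(-c2nnc(SCCCN3CCN(c4nc5ccccc5s4)CC3)o2)cc1`) gives 165000 nM. Compound 3 lies within the scatter of both other compounds, so these three numbers do not separate into a ranking. All of them are high numbers, which on this read-out stand for weak inhibition.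

Compound 4 (`c1ccc(-c2nnc(SCCCN3CCN(c4nc5ccccc5s4)CC3)o2)cc1`) has hydrogen in place of methoxy on an aromatic carbon. Within the data shown here, no measured pair shows this change. Among the measured compounds shown here, the nearest evidence is the single measured step, a 2.0-fold lower number from compound 1 to compound 2 (0.29 log units; within the scatter), where hydroxy takes the place of fluoro on an aromatic carbon. It is only a loose guide, since the core of compound 1 is not the core of compound 3. Still, that exchange of one small group for another did not move the number beyond the scatter, and nothing in the series points to a direction for the loss of methoxy. No step beyond the scatter is therefore expected in this assay.

The step expected is a 1.1-fold lower number from compound 3 to compound 4 (0.04 log units; within the scatter). The estimate for compound 4 is 150000 nM, with an expected range from 80000 nM to 280000 nM.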

Compound 4, half-maximal inhibitory concentration: 229000 nM
Compound 4: middle estimate off by 1.5-fold (0.18 log units), on the low side, within the range that was stated.
By their numbers in this assay, from the lowest: compounds 2, 3, 1 and 4 (each within the scatter of the next, the first and the last beyond it).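

In this assay, among these compounds, the change from 4-methoxyphenyl to phenyl gives a 1.4-fold higher number from compound 3 to compound 4 (0.14 log units; within the scatter), the first direct reading of a change at this place on the core of compound 3, on the six-membered aromatic ring of carbon only, para to a large group. The methoxy group, with its 2 heavy atoms and 1 hydrogen-bond acceptor, can therefore give way to hydrogen here without a step beyond the scatter, and the same holds on the core of compound 1 for the exchange of fluoro for hydroxy, a 2.0-fold lower number from compound 1 to compound 2 (0.29 log units; within the scatter), although that step rests on a different core and cannot be added to this one. No measurement at hand bears on why this exchange leaves the number within the scatter.

Still open, from the compounds shown here alone, is whether any group at this place can move the number beyond the scatter on the core of compound 3, for example an amine, a carboxylic acid or a longer chain such as butoxy. Also open, going by these compounds, is whether a change elsewhere in the shared structure, such as a longer chain in place of the propyl linker, would take these high numbers down further than any exchange on this ring has so far.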